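The source may report more compounds than this note shows. Statements on the series, on what has been measured and on what is new or still open speak of the compounds shown alone.

Measured so far:
- compound 1, `CCc1nc(C)c2n1CCN([C@@H](C(=O)NC)c1ccccc1)C2CCc1ccc(C(F)(F)F)cc1`: 24 nM
- compound 2, `CNC(=O)[C@@H](c1ccccc1)N1CCn2c(C(C)C)nc(Cl)c2[C@@H]1CCc1ccc(C(F)(F)F)cc1`: 11 nM
- compound 3, `CCc1nc(C2CC2)c2n1CCN([C@@H](C(=O)NC)c1ccccc1)[C@H]2CCc1ccc(C(F)(F)F)cc1`: 29 nM

All three were tested in a functional assay on CHO cells for antagonist activity at Orexin receptor type 2 (Homo sapiens), read by FLIPR and calcium flux; on this read-out lower numbers stand for stronger inhibition and higher numbers for weaker inhibition. Compound 1 gives 24 nM, which is the second highest of the three numbers. Its closest neighbour is compound 3 with 29 nM, a gap that sits within the usual scatter of this assay, so the two cannot be told apart. The furthest is compound 2 with 11 nM, a gap that lies beyond the scatter; compound 2 differs from compound 1 in more than one place, so no single change can be read out of that gap.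

The next compound, compound 4, is `CCc1nc(I)c2n1CCN([C@@H](C(=O)NC)c1ccccc1)C2CCc1ccc(C(F)(F)F)cc1`. Compared with compound 1 the change is iodo in place of methyl on an aromatic carbon. For the measured compounds named here, no pair of measured compounds differs in this one place alone, so there is no direct precedent for this exact step. The shared core seems to tolerate several small groups at this position without large swings in the numbers, as compounds 1 and 3 show. The step from compound 1 to compound 4 in this assay is therefore expected to be modest, estimated at a 1.6-fold lower number from compound 1 to compound 4 (0.20 log units; within the scatter), leaning toward a somewhat lower number. Compound 4 is thus estimated at 15 nM, with a range from 6 nM to 45 nM.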

Compound 4, half-maximal inhibitory concentration: 23 nM
Beside the measured number, compound 4's estimate is 1.5-fold (0.19 log units) below it; measured number inside the range.
By their numbers in this assay, from the lowest: compound 2; then compounds 4, 1 and 3 (each within the scatter of the next).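

In this assay, putting iodo in place of methyl on this aromatic carbon of the five-membered ring gives a 1.0-fold lower number from compound 1 to compound 4 (0.02 log units; within the scatter), so compound 1 and compound 4 cannot be told apart. This is the first step among the compounds shown that changes this position alone, whereas the other groups seen here, chloro in compound 2 and cyclopropyl in compound 3, come with further differences from compound 1; it shows that a swap from a carbon to an iodine, each a single heavy atom on this aromatic carbon, leaves the read-out within the scatter. No measurement shown bears on why the two numbers match.

Methyl and iodo both count no hydrogen-bond donors or acceptors and no net charge, so the compounds shown leave open how an amine or a carboxylic acid on this aromatic carbon would read in this assay. Both groups also have a single heavy atom, so a longer chain such as propyl, placed on the core of compound 1 with nothing else changed, remains an open question too.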